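Cyclopropyl on the carbamate nitrogen: from compound 2 to compound 4

The source may report more compounds than this note shows. Statements on the series, on what has been measured and on what is new or still open speak of the compounds shown alone.

Measured compounds:
compound 1 `COc1ccc(CC(=O)O)cc1-c1ccc(C(F)(F)F)cc1CN(C(=O)OCc1ccccc1)C1CCCC1` gives 53 nM
compound 2 `COc1ccc(CC(=O)O)cc1-c1ccc(C(F)(F)F)cc1CNC(=O)OCc1ccccc1` gives 709 nM
compound 3 `CCN(Cc1cc(C(F)(F)F)ccc1-c1cc(CC(=O)O)ccc1OC)C(=O)OCc1cc(F)cc(F)c1` gives 5 nM

In an assay on isolated protein for inhibition of prostaglandin D2 receptor 2 (Homo sapiens), read by flow cytometry, with stated times of 15 min and 5 min (a higher number here means a weaker inhibitor, a lower number a stronger inhibitor), compound 2 stands highest of the three numbers, so it is the weakest inhibitor of the set. Its nearest neighbour is compound 1, and the step of a 13-fold higher number from compound 1 to compound 2 (1.13 log units; beyond the scatter) shows how much is lost when the cyclopentyl on the amide-type nitrogen is replaced by hydrogen. Compound 3 lies further away still, but it differs from compound 2 in more than one place, so only its value can be compared, not a single change.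

Compound 4 `COc1ccc(CC(=O)O)cc1-c1ccc(C(F)(F)F)cc1CN(C(=O)OCc1ccccc1)C1CC1` has not yet been measured. It differs from compound 2 by cyclopropyl in place of hydrogen on an amide-type nitrogen. Among the measured compounds shown here, the one step that bears on this is the cyclopentyl-to-hydrogen step, a 13-fold higher number from compound 1 to compound 2 (1.13 log units; beyond the scatter), which was large and went in the direction of weaker inhibition when the ring was removed. Putting a ring back, here a three-membered one, is therefore expected to move the number in the opposite direction, though a ring of a different size need not recover the whole loss. The estimated step is a 6.4-fold lower number from compound 2 to compound 4 (0.81 log units; beyond the scatter), and compound 4 is expected at about 110 nM, in the range 30 nM to 400 nM.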

Compound 4, half-maximal inhibitory concentration: 10 nM
Compound 4: the middle estimate sits 11-fold (1.04 log units) above what was measured; measured number below the stated range.
By their numbers in this assay, from the lowest: compounds 3 and 4 (each within the scatter of the next); then compound 1; then compound 2.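

In this assay, among the compounds shown here, the amide-type nitrogen turns out to reward a small ring far more than the earlier compounds suggested: cyclopropyl in place of the hydrogen gives a 71-fold lower number from compound 2 to compound 4 (1.85 log units; beyond the scatter), a large step that takes compound 4 well past the level of compound 1. The direct comparison of the two rings gives a 5.3-fold lower number from compound 1 to compound 4 (0.72 log units; beyond the scatter), a modest step but one beyond the scatter, so at this position the identity of the ring matters and not only whether a ring is present; for these two rings, the smaller cyclopropyl gives the stronger inhibitor. Nothing available here accounts for this difference between cyclopropyl and cyclopentyl.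

With only these two rings and the bare hydrogen on this nitrogen in an otherwise unchanged benzyl carbamate, no trend with ring size can be drawn, and a cyclobutyl ring could fall anywhere relative to them. As far as these compounds go, it also remains open how an open branched group such as isopropyl, with similar carbons but no ring, would compare with cyclopropyl here.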